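Replacing Ethynyl with Bromopropenyl on a Trimethoxyphenyl Amide

The source may report more compounds than this note shows. Statements on the series, on what has been measured and on what is new or still open speak of the compounds shown alone.

Compound 1 `COc1cc(NCc2ccccc2)cc(OC)c1OC`: > 80000 nM
Compound 2 `C#CC(=O)N(Cc1ccc(OC)c(O)c1)c1cc(OC)c(OC)c(OC)c1`: 170 nM

Going by the values given here, in a functional assay on MGC-803 cells (Homo sapiens) for inhibition, read by MTT assay, with a stated time of 48 h (on this read-out higher numbers stand for weaker inhibition and lower numbers for stronger inhibition), compound 2 gives 170 nM, the only number among the values shown. Compound 1 sits at the limit of > 80000 nM in this assay, at which 1 of the 2 values shown sits, which is a limit of the assay and not a number. Compound 3 `COc1ccc(CN(C(=O)/C=C/CBr)c2cc(OC)c(OC)c(OC)c2)cc1O` differs from compound 2 by 3-bromoprop-1-en-1-yl in place of ethynyl on a carbonyl carbon. Among the compounds with values here, no measured step covers this change, so the author expects the step of a 1.8-fold higher number from compound 2 to compound 3 (0.25 log units; within the scatter) to fall within or only slightly beyond the scatter, if anything toward weaker inhibition. Compound 3 is accordingly estimated at 300 nM, with a range from 80 nM to 1500 nM.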

Compound 3, half-maximal inhibitory concentration: 71 nM
Compound 3: middle estimate off by 4.2-fold (0.63 log units), on the high side, outside the stated range (below it).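

Placing 3-bromoprop-1-en-1-yl in place of ethynyl on a carbonyl carbon gives a 2.4-fold lower number from compound 2 to compound 3 (0.38 log units; beyond the scatter) in this assay. This position therefore does not need the triple bond of compound 2 to give strong inhibition, and it accepts a longer chain with a double bond and a bromine. Nothing in the data shown accounts for this step. On these data alone, whether the bromine is needed remains open: a plain prop-1-en-1-yl chain or a 3-chloroprop-1-en-1-yl chain on the same carbonyl carbon could behave differently. So could a chain ending in an amine.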